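Fluoropyridinylmethyl isomers on a sulfonylated isatin core

The compounds below may be only part of what the source reports. "The series", "measured", "known", "first", "only" and "open" are said of these compounds alone.

Measured so far:
compound 1, `O=C1C(=O)N(Cc2ccnc(F)c2)c2ccc(S(=O)(=O)N3CCC[C@H]3COc3ccccc3)cc21`, > 50000 nM
compound 2, `O=C1C(=O)N(Cc2ccc(F)nc2)c2ccc(S(=O)(=O)N3CC[C@H]3COc3ccccc3)cc21`, > 50000 nM

In an assay on isolated protein for inhibition of Caspase-8 (Homo sapiens) (on this read-out higher numbers stand for weaker inhibition and lower numbers for stronger inhibition), compound 2 returns a limit rather than a number. Compound 1 likewise sits at a limit in this assay. For the measured compounds named here, both values therefore rest at the limit of > 50000 nM in this assay, at which 2 of the 2 values shown sit, and no step between the two can be measured; the pair shows only that neither reaches a quantifiable inhibition.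

Compound 3, `O=C1C(=O)N(Cc2cccc(F)n2)c2ccc(S(=O)(=O)N3CC[C@H]3COc3ccccc3)cc21`, is not yet measured. It differs from compound 2 by 6-fluoropyridin-2-yl in place of 6-fluoropyridin-3-yl on a saturated chain carbon bound to an amide-type nitrogen in a ring. Since compound 2 gives only a limit in this assay, the step from it cannot be sized on the data; the expectation for the move to compound 3 is a step that the limit leaves unreadable from compound 2 to compound 3, that is, no change beyond the scatter. Compound 3 is therefore expected at 60000 nM, with a range from 20000 nM to 200000 nM, and most likely it will again be reported only as a limit.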

Compound 3, half-maximal inhibitory concentration: > 50000 nM
Compound 3 gave a limit, no number (the forecaster's own chance of this, stated with the estimate: 85%); the middle value does not contradict the limit.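

In this assay, no step can be read from compound 2 to compound 3 because both rest at a limit: the limit of > 50000 nM in this assay, at which 3 of the 3 values shown sit.

The compounds shown leave open whether 6-fluoropyridin-2-yl and 6-fluoropyridin-3-yl differ at all, and what on the shared core could bring a readable number.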